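Swapping Methyl for Methylsulfonyl on the Amide Nitrogen

A few compounds are considered here, and "the series" means these few. Any claim that something is new, unique, unknown or untested is made for them only; others in the source may bear on it.

Compound 1, `Cc1n[nH]c(C(N)=O)c1Cc1cccc(-c2ccc(F)cc2)c1`: 14%
Compound 2, `CNC(=O)c1[nH]nc(C)c1Cc1cccc(-c2ccc(F)cc2)c1`: 19%

Both numbers come from an assay on isolated protein for inhibition of 2-Hydroxyacid oxidase 2 (Homo sapiens), tested at 10 uM; on this read-out higher numbers stand for a stronger effect at the one concentration tested and lower numbers for a weaker effect. Compound 2 stands with compound 1 inside the usual scatter of this read-out. Among the measured compounds shown here, the only measured step, a change on the amide-type nitrogen, reads a number 5 percentage points higher from compound 1 to compound 2 (within the scatter). Compound 3, `Cc1n[nH]c(C(=O)NS(C)(=O)=O)c1Cc1cccc(-c2ccc(F)cc2)c1`, has not been measured; it differs from compound 2 as follows: methylsulfonyl in place of methyl on an amide-type nitrogen. That earlier step at the same nitrogen stayed within the scatter, so for this change no step beyond the scatter is expected either: a number 1 percentage points lower from compound 2 to compound 3 (within the scatter). Compound 3 is therefore estimated at 18%, between 5% and 35%.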

Compound 3, a percentage reported as inhibition, at one concentration (the size of the read-out at that concentration, not a potency): 8%
Compound 3: middle estimate off by 10 percentage points, on the high side, and the stated range covers the measured number.
By their numbers in this assay, from the lowest: compounds 3, 1 and 2 (each within the scatter of the next, the first and the last beyond it).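

Methylsulfonyl on the amide-type nitrogen gives the first step at this position beyond the scatter, with a number 11 percentage points lower from compound 2 to compound 3 (beyond the scatter) in this assay when it replaces methyl. Set against hydrogen on the same nitrogen, the change reads a number 6 percentage points lower from compound 1 to compound 3 (within the scatter) and so stays within the scatter, which means the drop shows only against the methyl compound. Nothing measured here explains this step.
From the compounds shown here alone, it remains open how an acetyl group or a longer alkyl chain on this nitrogen would read. Going by these compounds, a carboxylic acid in place of the whole amide also remains open.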